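One Fluorophenyl Sulfonamide Change in a Cell Assay

The compounds below may be only part of what the source reports. "The series", "measured", "known", "first", "only" and "open" are said of these compounds alone.

- Compound 1 `CN1CCCN(CCNc2nccc(-c3c(-c4cccc(O)c4)nc4sccn34)n2)S1(=O)=O`: 36 nM
- Compound 2 `O=S(=O)(NCCCNc1nccc(-c2c(-c3cccc(O)c3)nc3sccn23)n1)c1cccc(F)c1`: 2600 nM
- Compound 3 `O=S(=O)(NCCNc1nccc(-c2c(-c3cccc(O)c3)nc3sccn23)n1)c1ccc(F)cc1`: not yet measured

In a functional assay on Malme-3M cells (Homo sapiens) for inhibition, read by sulforhodamine B assay, with a stated time of 48 h (on this read-out lower numbers stand for stronger inhibition and higher numbers for weaker inhibition), compound 2 has the higher number of the two, at 2600 nM. Compound 3 differs from it at one place, on a saturated chain carbon, two bonds along the chain from a nitrogen on an aromatic ring: ((4-fluorophenyl)sulfonyl)amino in place of (((3-fluorophenyl)sulfonyl)amino)methyl on a saturated chain carbon, two bonds along the chain from a nitrogen on an aromatic ring. Going by the values given here, the only measured step, a 72-fold higher number from compound 1 to compound 2 (1.86 log units; beyond the scatter), is large and replaced the whole group at that place, with the larger group giving the higher number. Here, the six-membered aromatic ring of carbon only remains, and the entering group is slightly smaller, so a more modest fall in this assay is expected. The estimated value for compound 3 is 800 nM, with an expected range of 120 nM to 4500 nM. This estimate means a 3.3-fold lower number from compound 2 to compound 3 (0.51 log units; beyond the scatter).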

Compound 3, half-maximal inhibitory concentration: 279 nM
Compound 3: the middle estimate sits 2.9-fold (0.46 log units) above what was measured; the measured number falls inside the stated range.
By their numbers in this assay, from the lowest: compound 1; then compound 3; then compound 2.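

The swap at this place gives a 9.3-fold lower number from compound 2 to compound 3 (0.97 log units; beyond the scatter) in this assay even though the six-membered aromatic ring stays, so this position responds strongly to a change of one carbon together with a new fluorine location. There is still a 7.8-fold higher number from compound 1 to compound 3 (0.89 log units; beyond the scatter) and so the six-membered non-aromatic ring of compound 1 keeps the lowest number of the three. Nothing available here explains these differences.

On these data alone, the step changes the carbon count and the fluorine location together, and their separate shares remain open. Either ((3-fluorophenyl)sulfonyl)amino or an unfluorinated (phenylsulfonyl)amino group at this place could begin to separate them.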